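The source may hold more compounds than are shown below. What is called first, only, known or untested is meant among the compounds shown, and "the series" means these compounds.

Measured compounds in a functional assay on HT-29 cells (Homo sapiens) for cytotoxicity, read by sulforhodamine B assay, with a stated time of 48 h; on this read-out higher numbers stand for weaker inhibition and lower numbers for stronger inhibition:
compound 1 `CCNC(=O)Nc1cccc(S(=O)(=O)Oc2ccccc2CC)c1`, 33000 nM
compound 2 `CCCc1ccccc1OS(=O)(=O)c1cccc(NC(=O)NCC)c1`, 25000 nM
compound 3 `CCNC(=O)Nc1ccc(S(=O)(=O)Nc2ccccc2CC)cc1`, 86000 nM

The change from compound 1 to compound 2 is methyl in place of hydrogen on a saturated chain carbon, two bonds along the chain from an aromatic carbon; it made a step of a 1.3-fold lower number from compound 1 to compound 2 (0.12 log units; within the scatter). Compound 3 has a different core, and the difference between the two cores is not broken down here. Compound 3 gives the highest number of the three, beyond the scatter from compound 1 and from compound 2. Compound 4 `CCCc1ccccc1NS(=O)(=O)c1ccc(NC(=O)NCC)cc1` is not yet measured; it differs from compound 3 by methyl in place of hydrogen on a saturated chain carbon, two bonds along the chain from an aromatic carbon, the same change seen once before in this set. Going by the values given here, for compound 4 in this assay a step of a 1.2-fold lower number from compound 3 to compound 4 (0.09 log units; within the scatter) is expected, resting only on the single earlier step of a 1.3-fold lower number from compound 1 to compound 2 (0.12 log units; within the scatter), which lay within the scatter. The estimate for compound 4 is 70000 nM, with a range from 30000 nM to 160000 nM.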

Compound 4, half-maximal inhibitory concentration: 32000 nM
For compound 4 the middle estimate is 2.2-fold (0.34 log units) above the measured one; measured number inside the range.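

In this assay, the added methyl gives a 2.7-fold lower number from compound 3 to compound 4 (0.43 log units; beyond the scatter), so on this core the change from ethyl to propyl goes with a lower number. Set beside the earlier step, this one does not differ beyond the scatter of two such steps: the same change on two cores in this assay, a 1.3-fold lower number (0.12 log units; within the scatter) from compound 1 to compound 2 and a 2.7-fold lower number (0.43 log units; beyond the scatter) from compound 3 to compound 4, 2.0-fold (0.31 log units) apart, within the scatter of two such steps. This is compatible with the change carrying over from one core to the other, but two pairs do not fix a shared size, and with the earlier step within the scatter, a lowering on both cores is not shown.

As far as these compounds go, only ethyl and propyl appear on these cores, so the outcome with a longer chain such as butyl remains open. From the compounds shown here alone, an amine or a carboxylic acid at the end of the chain also remains open.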